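Working notes on a small aryl-amino series

This account rests on a few compounds, and the source may have more. Where it says the series, first, only, none or still open, it means among the compounds named here.

Of the compounds shown here, three sharing one core have been measured in an assay on mitochondria from L6 cells (Rattus norvegicus) for activation, with a stated time of 90 min; on this read-out lower numbers stand for an effect already at smaller amounts and higher numbers for an effect only at larger amounts of compound. Compound 1 `COc1cccc(Nc2nc3nonc3nc2O)c1` gives 75400 nM. Compound 2 `CCCCOc1ccc(Nc2nc3nonc3nc2O)cc1` gives 3700 nM, and compound 3 `Oc1nc2nonc2nc1Nc1ccc(OCCCC(F)(F)F)c(F)c1` gives 4200 nM. Compound 2 thus carries the lowest of the three numbers; compound 3 lies within the usual scatter of it, so no order between these two can be stated, whereas compound 1 shows a clearly higher number, beyond the scatter. Compound 4 `CCCCc1ccc(Nc2nc3nonc3nc2O)cc1` has not yet been measured. It differs from compound 2 in a single place: butyl in place of butoxy on an aromatic carbon. For the measured compounds named here, no measured pair reports this kind of change, so the direction rests on expectation alone. A modest rise in the number is expected, near the edge of the scatter, as the expected step of a 1.6-fold higher number from compound 2 to compound 4 (0.21 log units; within the scatter). For compound 4 the estimated value in this assay is 6000 nM, with a range from 1800 nM to 20000 nM.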

Compound 4, half-maximal effective concentration: 2100 nM
Compound 4: the middle estimate sits 2.9-fold (0.46 log units) above what was measured; the range from low to high includes it.
By their numbers in this assay, from the lowest: compounds 4, 2 and 3 (each within the scatter of the next); then compound 1.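

In this assay the butoxy group on an aromatic carbon, para to a large group, gives way to butyl with a 1.8-fold lower number from compound 2 to compound 4 (0.25 log units; within the scatter) and no change can be stated. The oxygen of butoxy, the one hydrogen-bond acceptor leaving, is thus not needed at this place for a number in this range. Nothing at hand explains this result.

Going by these compounds, whether an amine or a carboxylic acid at this place keeps the number in this range stays open. So does the outcome for a chain longer than butyl.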